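The compounds below may be only part of what the source reports. "The series", "measured", "known", "first", "only" and "open" are said of these compounds alone.

Going by the values given here, compound 1, with structure `O=C(/C=C/c1ccc([N+](=O)[O-])cc1)Nc1cc2c(Nc3ccc(F)c(Cl)c3)ncnc2cc1O[C@H]1CCOC1`, is the only member of this small set for which a number was obtained. In a functional assay on MCF7 cells (Homo sapiens) for cytotoxicity, read by MTT assay, with a stated time of 72 h (a lower number here means a stronger inhibitor, a higher number a weaker inhibitor), compound 1 gives 26700 nM, which places it as a weak inhibitor in absolute terms. Among the compounds with values here, it is the reference point here simply as the one compound that produced a figure. Compound 2, with structure `COc1ccc(/C=C/C(=O)Nc2cc3c(Nc4ccc(F)c(Cl)c4)ncnc3cc2OC)cc1`, was recorded in this assay as "not active" (no number reported). Compound 3, with structure `COc1cc2ncnc(Nc3ccc(F)c(Cl)c3)c2cc1NC(=O)/C=C/c1ccc(F)cc1Cl`, was likewise recorded in this assay as "not active" (no number reported). No pair among these three differs in only one place, so no single step can be read off between them; all that can be said is that compound 1 shows a number where compounds 2 and 3 show none.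

Compound 4, with structure `O=C(/C=C/c1ccccc1[N+](=O)[O-])Nc1cc2c(Nc3ccc(F)c(Cl)c3)ncnc2cc1O[C@H]1CCOC1`, keeps every atom of compound 1 and rearranges only the nitro-bearing ring: 2-nitrophenyl in place of 4-nitrophenyl on a double-bonded chain carbon bound to a double-bonded chain carbon. Within the data shown here, with no comparable step measured anywhere in the set, the expected change in this assay from compound 1 to compound 4 is small, and is estimated as a 1.3-fold higher number from compound 1 to compound 4 (0.12 log units; within the scatter), at or a little beyond the scatter toward weaker inhibition. In this assay compound 4 is therefore expected to give about 35000 nM, in a range from 12000 nM to 100000 nM.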

Compound 4, half-maximal inhibitory concentration: 28400 nM
The estimate for compound 4 lay 1.2-fold (0.09 log units) above the measured number; the range from low to high includes it.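

In this assay, going by these compounds alone, the change gives the first step that can be read, a 1.1-fold higher number from compound 1 to compound 4 (0.03 log units; within the scatter), and that step lies within the scatter. Moving from the earlier compounds, which offered no comparison in one place, this pair shows that 2-nitrophenyl in place of 4-nitrophenyl on a double-bonded chain carbon bound to a double-bonded chain carbon leaves two values that cannot be told apart, so this assay does not separate these two placements of the nitro group on the phenyl ring. No independent measurement bears on this result, so the reading rests on the two values alone.

The compounds shown leave open whether an amine or a carboxylic acid in place of the nitro group on that phenyl ring would give a number distinguishable from those of compound 1 and compound 4 in this assay. They also leave open whether a longer chain in place of the ethenyl link would shift the reading beyond the scatter.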